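Swapping a Nitrophenoxy Arm for a Phenylsulfonyl Arm

A few compounds are considered here, and "the series" means these few. Any claim that something is new, unique, unknown or untested is made for them only; others in the source may bear on it.

The three measured compounds were all tested in an ADME assay on BJ cells (Homo sapiens) for antiproliferative activity, with a stated time of 72 h (on this read-out higher numbers stand for an effect only at larger amounts of compound and lower numbers for an effect already at smaller amounts), and each result is a limit of the assay rather than a number.

Compound 1 `COC(=O)c1cc(=O)c2c(OC)cc(OC)cc2[nH]1` gives a limit, > 34400 nM.
Compound 2 `COC(=O)c1cc(=O)c2c(OC)cc(OC)cc2n1C` gives a limit, > 37900 nM.
Compound 3 `COc1cc(OC)c2c(=O)cc(C(=O)Nc3ccc(Oc4ccc([N+](=O)[O-])cc4)cc3)[nH]c2c1` gives a limit, > 22900 nM.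

Compound 3 thus stands only at a limit, as the other two do (the limit of > 22900 nM in this assay, at which 1 of the 3 values shown sits). Among the measured compounds shown here, the single step between measured compounds, a step that the two limits leave unreadable from compound 1 to compound 2, is unreadable because both ends are limits the limit of > 34400 nM in this assay, at which 1 of the 3 values shown sits (the limit of > 37900 nM in this assay, at which 1 of the 3 values shown sits). Compound 4 `COc1cc(OC)c2c(=O)cc(C(=O)Nc3ccc(S(=O)(=O)c4ccccc4)cc3)[nH]c2c1` differs from compound 3 by phenylsulfonyl in place of 4-nitrophenoxy on an aromatic carbon. No readable step bears on this change, so no shift beyond the scatter is expected, and a limit is again the likeliest outcome. Compound 4 is therefore estimated at 30000 nM (range 10000 nM to 100000 nM), an expected step that the limit leaves unreadable from compound 3 to compound 4 within the scatter.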

Compound 4, half-maximal effective concentration: > 70600 nM
Compound 4: only a limit was reported; the forecaster's own chance of this, stated with the estimate: 75%; middle value at least 2.3-fold (0.37 log units) away from the limit.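

Among the compounds shown here, compound 3 and compound 4 both give only a limit of the assay, so no step between them can be read. The compounds shown leave open whether phenylsulfonyl or 4-nitrophenoxy gives any measurable effect in this assay.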